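Swapping the aryl group on the piperazine of compound 1

This account rests on a few compounds, and the source may have more. Where it says the series, first, only, none or still open, it means among the compounds named here.

Compound 1 `Cc1ccc(N2CCN(C(=O)c3oc(C)nc3-c3ccccc3)CC2)cc1` is one of three members of a small set that share the same core. In a functional assay on HL-60 cells (Homo sapiens) for inhibition, read by MTT assay, with a stated time of 72 h (a higher number here means a weaker inhibitor, a lower number a stronger inhibitor), compound 1 gives only a limit, > 1000 nM, and not a number. In this assay compound 2 `CCc1nc(-c2ccc(C(C)C)cc2)c(C(=O)N2CCN(c3cccc(OC)c3)CC2)o1` gives 887 nM. For compound 3 `Cc1nc(-c2ccccc2)c(C(=O)N2CCN(c3ccc(C(=O)C(C)C)cc3)CC2)o1` the result in this assay is "not active" (no number reported), again with no number attached. Compound 1 therefore stands at the limit of > 1000 nM in this assay, at which 1 of the 3 values shown sits, alongside one further entry that carries no number, so the set as a whole sits at the weak end of what this assay can resolve. Among the measured compounds shown here, no step between two measured compounds that differ in one place is available here.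

Compound 4 `Cc1nc(-c2ccccc2)c(C(=O)N2CCN(c3ccc(Cl)c(Cl)c3)CC2)o1` has not been measured. It differs from compound 1 in one place: 3,4-dichlorophenyl in place of 4-methylphenyl on an amine nitrogen in a ring. For the measured compounds named here, with compound 1 at a limit and compound 3 without a number, there is no measured step from which to read the effect of this change. The expectation is that compound 4 remains weak, and the step from compound 1 to compound 4, a step that the limit leaves unreadable from compound 1 to compound 4, is estimated to be small, with no direction beyond the scatter claimed. In this assay compound 4 is estimated at 1500 nM, within a range from 400 nM to 6000 nM.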

Compound 4, half-maximal inhibitory concentration: 124 nM
Estimate against measurement, compound 4: 12-fold (1.08 log units) above, outside the stated range (below it).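

In this assay, replacing 4-methylphenyl with 3,4-dichlorophenyl on an amine nitrogen in a ring gives an at least 8.0-fold lower number from compound 1 to compound 4 (0.90 log units; beyond the scatter), which shows that the group at this position can decide whether the core of compound 1 gives a measurable effect. Among the compounds shown here, with this change, compound 4 reaches 124 nM, so this position is not confined to the weak end of the assay, as the earlier entries alone might have suggested, although no step to compound 4 from compound 3, which has no number, can be read. The true size of the change remains open, and only a minimum is known, because the entry for compound 1 is a limit and not a number: the limit of > 1000 nM in this assay, at which 1 of the 4 values shown sits.

The compounds shown leave open whether both chlorine atoms are needed, since neither 4-chlorophenyl nor 3-chlorophenyl appears among them at this position. They also do not show whether another halogen, such as bromine or fluorine, or a trifluoromethyl group on the same aromatic ring would give a value like that of compound 4.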